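A few compounds are considered here, and "the series" means these few. Any claim that something is new, unique, unknown or untested is made for them only; others in the source may bear on it.

Of the compounds shown here, three built on one shared core have been measured in a functional assay on MCF7 cells (Homo sapiens) for inhibition, read by MTT assay, with a stated time of 48 h; on this read-out higher numbers stand for weaker inhibition and lower numbers for stronger inhibition. Compound 1 `Clc1ccccc1CSc1nnc(-c2ccncc2)n1-c1ccccc1` gives 18100 nM, compound 2 `Clc1ccc(CSc2nnc(-c3ccncc3)n2-c2ccccc2)cc1` gives 13300 nM, and compound 3 `c1ccc(CSc2nnc(-c3ccncc3)n2-c2ccccc2)cc1` gives 22400 nM. Compound 3 stands at the high end of these three numbers, yet both steps leading to it stay within the scatter: a 1.2-fold higher number from compound 1 to compound 3 (0.09 log units; within the scatter) and a 1.7-fold higher number from compound 2 to compound 3 (0.23 log units; within the scatter). Compound 4 `O=[N+]([O-])c1ccc(CSc2nnc(-c3ccncc3)n2-c2ccccc2)cc1` differs from compound 3 by nitro in place of hydrogen on an aromatic carbon. The step from compound 2 to compound 3 bears most on this change. The 4-chlorophenyl of compound 2 and the 4-nitrophenyl of compound 4 each carry a single group on an aromatic carbon of an otherwise bare phenyl, and that step was small. The step from compound 1 to compound 3 was small as well. So only a small shift is expected in this assay, if any, toward a lower number. Compound 4 is therefore estimated at 14000 nM, with a range from 7000 nM to 28000 nM, which means an expected step of a 1.6-fold lower number from compound 3 to compound 4 (0.20 log units; within the scatter).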

Compound 4, half-maximal inhibitory concentration: 22800 nM
Estimate against measurement, compound 4: 1.6-fold (0.21 log units) below; the measured number falls inside the stated range.
By their numbers in this assay, from the lowest: compounds 2, 1, 3 and 4 (each within the scatter of the next).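

In this assay, nitro in place of hydrogen gives a 1.0-fold higher number from compound 3 to compound 4 (0.01 log units; within the scatter), so a group of three heavy atoms with two hydrogen-bond acceptors, para to a large group, joins chloro as a second substituent at this place that stays within the scatter of the bare phenyl. Nitro in place of chloro gives a 1.7-fold higher number from compound 2 to compound 4 (0.23 log units; within the scatter), and 4-nitrophenyl in place of 2-chlorophenyl gives a 1.3-fold higher number from compound 1 to compound 4 (0.10 log units; within the scatter), so all four compounds now lie within the scatter of one another and these changes on this ring have not yet separated any pair. Nothing available here offers an explanation for this flat result.

As far as these compounds go, it remains open whether an amine or a carboxylic acid at this place, or a longer chain between the sulfur and the ring, would move the number beyond the scatter. From the compounds shown here alone, whether changes elsewhere on the shared core would do so is equally open.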